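The source may report more compounds than this note shows. Statements on the series, on what has been measured and on what is new or still open speak of the compounds shown alone.

In a functional assay on 786-0 cells (Homo sapiens) for inhibition, read by sulforhodamine B assay, with a stated time of 48 h (a lower number here means a stronger inhibitor of growth, a higher number a weaker inhibitor of growth), compound 1 `CC1(/C=C/c2ccccc2)C=CC(=O)O1` gives 170000 nM. Compound 2 `CC1(/C=C/c2ccccc2O)C=CC(=O)O1`, at 136000 nM, cannot be told apart from it, with a 1.3-fold lower number from compound 1 to compound 2 (0.10 log units; within the scatter). Compound 3 `COc1ccccc1/C=C/C1(C)C=CC(=O)O1`, at 35400 nM, lies lower than both, so compound 1 stands at the high end of this small set. Compound 4 `COc1cccc(/C=C/C2(C)C=CC(=O)O2)c1` differs from compound 1 by one change: methoxy in place of hydrogen on an aromatic carbon. The closest guide is compound 3, which carries the same group at another place on the ring and shows a 4.8-fold lower number from compound 1 to compound 3 (0.68 log units; beyond the scatter). With the place changed, a step in the same direction but smaller is expected, and the expected step is a 2.4-fold lower number from compound 1 to compound 4 (0.39 log units; beyond the scatter). The estimate for compound 4 is 70000 nM, with an expected range of 28000 nM to 160000 nM.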

Compound 4, concentration for total growth inhibition: 70000 nM
Compound 4: the middle estimate sits on the measured number at the digits printed; the range from low to high includes it.
By their numbers in this assay, from the lowest: compounds 3, 4, 2 and 1 (each within the scatter of the next, the first and the last beyond it).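

Methoxy in place of hydrogen still gives a 2.4-fold lower number from compound 1 to compound 4 (0.39 log units; beyond the scatter) when it sits meta to a group of 9 heavy atoms, so in this assay a step beyond the scatter is not confined to the place the methoxy holds in compound 3. Compound 3 and compound 4 lie within the scatter of each other, so these numbers do not separate the two places.

Going by these compounds, whether an amine, a carboxylic acid or a longer chain such as ethoxy would give a similar step at this place remains open. Nothing available explains the step itself.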